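Shortening the chain: an expectation for compound 3

The source may hold more compounds than are shown below. What is called first, only, known or untested is meant among the compounds shown, and "the series" means these compounds.

Measured in a functional assay on HeLa cells (Homo sapiens) for inhibition, read by MTT assay, with a stated time of 72 h; on this read-out higher numbers stand for weaker inhibition and lower numbers for stronger inhibition:
Compound 1 `Nc1nc2cc(-c3nn(CCCCC(=O)NO)c4ncnc(N)c34)ccc2o1`: 32200 nM
Compound 2 `Nc1nc2cc(-c3nn(CCCCCC(=O)NO)c4ncnc(N)c34)ccc2o1`: 15400 nM

Compound 2 holds the lower of the two numbers, at 15400 nM, which makes it the stronger inhibitor of this pair. Among the measured compounds shown here, its only comparison is compound 1, at 32200 nM.

The next compound, compound 3 `Nc1nc2cc(-c3nn(CC(=O)NO)c4ncnc(N)c34)ccc2o1`, keeps the core of compound 2 and differs in one place: hydroxycarbamoyl in place of 4-(hydroxycarbamoyl)butyl on a saturated chain carbon bound to an aromatic nitrogen. In words, hydroxycarbamoyl stands in place of 4-(hydroxycarbamoyl)butyl on a saturated chain carbon bound to an aromatic nitrogen.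

For the measured compounds named here, one measured step bears on this change: a 2.1-fold lower number from compound 1 to compound 2 (0.32 log units; beyond the scatter). That modest step came with a longer chain. Going by the values given here, compound 3 goes the opposite way, and its chain change is larger than the one in that step, so a higher number is expected in this assay. Two compounds make only a thin trend, and no chain as short as that of compound 3 has been measured, so the size remains uncertain. The expected change is a 3.2-fold higher number from compound 2 to compound 3 (0.51 log units; beyond the scatter). For compound 3 the estimated value is 50000 nM, with an expected range of 18000 nM to 130000 nM.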

Compound 3, half-maximal inhibitory concentration: > 150000 nM
Compound 3: a limit, no number (the forecaster's own chance of this, stated with the estimate: 25%); at least 3.0-fold (0.47 log units) between middle value and limit.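

In this assay, compound 3 gives a limit of the assay and not a number: the limit of > 150000 nM in this assay, at which 1 of the 3 values shown sits. Replacing 4-(hydroxycarbamoyl)butyl with hydroxycarbamoyl on the saturated chain carbon bound to an aromatic nitrogen gives an at least 9.7-fold higher number from compound 2 to compound 3 (0.98 log units; beyond the scatter), and replacing 3-(hydroxycarbamoyl)propyl with hydroxycarbamoyl gives an at least 4.6-fold higher number from compound 1 to compound 3 (0.66 log units; beyond the scatter). The earlier pair offered one modest step, whereas these three compounds now run in a single direction, with none going against it: the shorter the chain, the higher the number, and the shortest chain gives a step that can be stated only as a minimum.

The compounds shown leave open how the number changes at a chain length intermediate to those of compound 3 and compound 1, such as a 2-(hydroxycarbamoyl)ethyl group, and whether a chain longer than that of compound 2 would lower the number further. They also leave open whether the trend depends on the hydroxycarbamoyl end of the chain, which a carboxylic acid or a primary amide in its place could test.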